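The source may hold more compounds than are shown below. What is called first, only, known or untested is meant among the compounds shown, and "the series" means these compounds.

Compound 1, `C=CC(=O)Nc1cccc(NC(=O)CSc2nc(Nc3ccccc3C)c3ccccc3n2)c1`, gives 20400 nM in a functional assay on MDA-MB-231 cells (Homo sapiens) for inhibition, read by MTT assay, with a stated time of 72 h; a higher number here means a weaker inhibitor, a lower number a stronger inhibitor.
Compound 2, `C=CC(=O)Nc1cccc(NC(=O)CSc2nc(Nc3cccc(F)c3)c3ccccc3n2)c1`, gives 8160 nM in this assay.
Compound 3, `C=CC(=O)Nc1cccc(NC(=O)CSc2nc(Nc3cccc(OC)c3)c3ccccc3n2)c1`, gives 12900 nM in this assay.

Compound 3 sits between the other two on these numbers, but the step of a 1.6-fold lower number from compound 1 to compound 3 (0.20 log units; within the scatter) and the step of a 1.6-fold higher number from compound 2 to compound 3 (0.20 log units; within the scatter) both lie within the scatter, so no order among compound 3 and its neighbours can be read. Going by the values given here, only the step of a 2.5-fold lower number from compound 1 to compound 2 (0.40 log units; beyond the scatter) goes beyond the scatter, and then only modestly. Compound 4, `C=CC(=O)Nc1cccc(NC(=O)CSc2nc(Nc3ccc(C(F)(F)F)cc3)c3ccccc3n2)c1`, differs from compound 3 in one place: 4-(trifluoromethyl)phenyl in place of 3-methoxyphenyl on a nitrogen on an aromatic ring. Among the compounds with values here, all three measured steps vary the same aryl group on that nitrogen, and none of them moves the number far; none of them brings in a trifluoromethyl group, and none carries a phenyl substituted as in compound 4, so the new change has no direct precedent. The step to compound 4 is therefore expected to be small and of uncertain direction, the estimate being a 1.3-fold lower number from compound 3 to compound 4 (0.11 log units; within the scatter). Compound 4 is expected to give about 10000 nM in this assay, within a range from 4000 nM to 25000 nM.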

Compound 4, half-maximal inhibitory concentration: 11500 nM
Compound 4: the middle estimate sits 1.2-fold (0.06 log units) below what was measured, and the stated range covers the measured number.
By their numbers in this assay, from the lowest: compounds 2, 4, 3 and 1 (each within the scatter of the next, the first and the last beyond it).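

In this assay, the 4-(trifluoromethyl)phenyl group on this nitrogen gives a 1.1-fold lower number from compound 3 to compound 4 (0.05 log units; within the scatter), and the steps of a 1.4-fold higher number from compound 2 to compound 4 (0.15 log units; within the scatter) and a 1.8-fold lower number from compound 1 to compound 4 (0.25 log units; within the scatter) are equally unresolved, so compound 4 cannot be separated from any of the other three compounds. This extends the earlier picture to a new trifluoromethyl group and a new substitution pattern on the phenyl ring: across this change, with fluorine entering and oxygen leaving, the number stays within the scatter. No measured evidence bearing on this result is available.

As far as these compounds go, it remains open whether an amine or a carboxylic acid on this phenyl ring, or a longer alkyl chain in its place, would move the number beyond the scatter. From the compounds shown here alone, all four compounds also share the rest of their structure, so the effect of a change elsewhere remains unknown.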